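A few compounds are considered here, and "the series" means these few. Any claim that something is new, unique, unknown or untested is made for them only; others in the source may bear on it.

Of the compounds shown here, three built on one shared core have so far been measured in an ADME assay on isolated protein for inhibition of Amine oxidase [flavin-containing] A (Homo sapiens), read by fluorescence and Amplex Red, with stated times of 15 min and 20 min; on this read-out higher numbers stand for weaker inhibition and lower numbers for stronger inhibition. Compound 1 `C#CCN(CCCCOc1ccc2ccc(=O)oc2c1)Cc1ccc(C(C)C)cc1` gives 35400 nM in this assay. Compound 2 `C#CCN(CCCCOc1ccc2ccc(=O)oc2c1)Cc1ccc(C)cc1` gives 94500 nM. Compound 3 `C#CCN(CCCOc1ccc2ccc(=O)oc2c1)Cc1cccc(F)c1`, which differs from the other two both in its chain and in the group on its aromatic ring, gives 29300 nM. Compound 2 therefore stands at the top of these three numbers, meaning it is the weakest inhibitor of the set, with compound 1 nearest below it and compound 3 furthest below.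

The next compound, compound 4 `C#CCN(CCCCOc1ccc2ccc(=O)oc2c1)Cc1ccc(F)c(F)c1`, differs from compound 2 in one place: 3,4-difluorophenyl in place of 4-methylphenyl on a saturated chain carbon bound to an amine nitrogen. Within the data shown here, only one measured step alters the same part of the molecule, the one in which a 2.7-fold higher number from compound 1 to compound 2 (0.43 log units; beyond the scatter); a change of one group on an aromatic carbon thus shifted the number by a modest amount. Among the measured compounds shown here, no measured pair exchanges a methyl group for fluorine atoms on this ring, so direction rests on a loose analogy: compound 3 sits lower than compound 2, but it also differs in the chain, so its value cannot be read as a clean step. A modest move toward a lower number is therefore expected, namely a 2.4-fold lower number from compound 2 to compound 4 (0.37 log units; beyond the scatter), while an outcome within the scatter would not surprise. Compound 4 is accordingly estimated at 40000 nM, with a range from 12000 nM to 130000 nM.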

Compound 4, half-maximal inhibitory concentration: 93200 nM
Estimate against measurement, compound 4: 2.3-fold (0.37 log units) below; low and high end bracket the measured number.
By their numbers in this assay, from the lowest: compounds 3 and 1 (each within the scatter of the next); then compounds 4 and 2 (each within the scatter of the next).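

In this assay, setting 3,4-difluorophenyl in place of 4-methylphenyl gives a 1.0-fold lower number from compound 2 to compound 4 (0.01 log units; within the scatter), so at this position, on a saturated chain carbon bound to an amine nitrogen, the two groups cannot be told apart despite their different atoms. Setting 3,4-difluorophenyl in place of 4-isopropylphenyl gives a 2.6-fold higher number from compound 1 to compound 4 (0.42 log units; beyond the scatter), a step close in size to a 2.7-fold higher number from compound 1 to compound 2 (0.43 log units; beyond the scatter), so among the three compounds sharing this chain, compound 1 alone stands apart, with the lower number. No other measurement is available that bears on this result.

With only three groups compared on this chain, the compounds shown cannot tell whether the lower number of compound 1 belongs to 4-isopropylphenyl alone or would also appear with a group such as 4-tert-butylphenyl, 4-methoxyphenyl or 4-chlorophenyl. From the compounds shown here alone, compound 3 differs from the others in both its chain and its ring group, so the part played by chain length stays open, and only a pair differing in the chain alone, or one carrying a longer chain, could separate it.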